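This account rests on a few compounds, and the source may have more. Where it says the series, first, only, none or still open, it means among the compounds named here.

Compound 2 `C=C1[C@@H](OC(C)=O)C[C@@H]2[C@](C)(COC=O)[C@H](OC(C)=O)CC[C@@]2(C)[C@@H]1C[C@@H](Nc1ccc(OC)c(OC)c1)C1=CCOC1=O` is one of three compounds already tested in a functional assay on A549 cells (Homo sapiens) for cytotoxicity, read by sulforhodamine B assay; a higher number here means a weaker inhibitor, a lower number a stronger inhibitor. Compound 2 gives > 50000 nM in this assay, which is a limit of the assay rather than a number. This places compound 2 at the limit of > 50000 nM in this assay, at which 1 of the 3 values shown sits, so its true standing is open toward weaker values only. The two other measured compounds carry a silyl-protected alcohol in place of the formate of compound 2: compound 1 `C=C1[C@@H](OC(C)=O)C[C@@H]2[C@](C)(CO[Si](C)(C)C(C)(C)C)[C@H](OC(C)=O)CC[C@@]2(C)[C@@H]1C[C@@H](Nc1ccccc1)C1=CCOC1=O` gives 4500 nM in this assay, and compound 3 `C=C1[C@@H](OC(C)=O)C[C@@H]2[C@](C)(CO[Si](C)(C)C(C)(C)C)[C@H](OC(C)=O)CC[C@@]2(C)[C@@H]1C[C@@H](Nc1ccc(F)cc1)C1=CCOC1=O` gives 4550 nM in this assay.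

Compound 4 `C=C1[C@@H](OC(C)=O)C[C@@H]2[C@](C)(COC=O)[C@H](OC(C)=O)CC[C@@]2(C)[C@@H]1C[C@@H](Nc1cccc(F)c1)C1=CCOC1=O` has not yet been measured. It differs from compound 2 by 3-fluorophenyl in place of 3,4-dimethoxyphenyl on an amine nitrogen. Within the data shown here, the only measured step that touches the aryl ring on the amine nitrogen is a 1.0-fold higher number from compound 1 to compound 3 (0.00 log units; within the scatter), a small change that left the number where it was. Among the measured compounds shown here, the change from compound 2 to compound 4 is larger, removing both methoxy groups and adding a fluorine, and no measured step covers that exchange; since compound 2 itself sits at a limit, the starting point is also uncertain.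

He therefore expects compound 4 to reach 30000 nM in this assay, within a range from 6000 nM to 150000 nM, corresponding to an estimated step of an at least 1.6-fold lower number from compound 2 to compound 4 (0.22 log units; that floor lies within the scatter).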

Compound 4, half-maximal inhibitory concentration: 23200 nM
Compound 4: the middle estimate sits 1.3-fold (0.11 log units) above what was measured, within the range that was stated.
By their numbers in this assay, from the lowest: compounds 1 and 3 (each within the scatter of the next); then compound 4. At a limit, above all of these: compound 2.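

Set against the earlier aryl change, a 1.0-fold higher number from compound 1 to compound 3 (0.00 log units; within the scatter), this result shows that the aryl ring on the amine nitrogen is not a silent position in this assay. Exchanging 3,4-dimethoxyphenyl for 3-fluorophenyl at this place gives an at least 2.1-fold lower number from compound 2 to compound 4 (0.33 log units; beyond the scatter), the first change at this ring in the compounds shown that lies beyond the scatter, and it appears in compounds carrying the formate rather than the silyl-protected alcohol. On these data alone, the size of this step is only a floor, and its true size stays unknown, because compound 2 stands at a limit of the assay: the limit of > 50000 nM in this assay, at which 1 of the 4 values shown sits.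

The compounds shown do not separate the loss of the two methoxy groups from the entry of the fluorine, and a plain phenyl group or a phenyl group carrying one methoxy group on the formate compounds would be needed to tell these apart. As far as these compounds go, the part played by the formate against the silyl-protected alcohol also stays open, since compound 4 differs from compound 1 and from compound 3 in more than one place, and neither pair can be compared directly.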